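The compounds below may be only part of what the source reports. "The series", "measured", "known", "first", "only" and "open" are said of these compounds alone.

Measured so far in a functional assay on MDA-MB-231 cells (Homo sapiens) for antiproliferative activity, read by CCK-8 assay, with a stated time of 72 h; a higher number here means a weaker inhibitor, a lower number a stronger inhibitor:
Compound 1 `CC1=NN(c2ccc(C)cc2)C(=O)C12C=CC(=O)C=C2c1ccccc1` gives 46600 nM.
Compound 2 `CC1=NN(c2ccc(Br)cc2)C(=O)C12C=CC(=O)C=C2c1ccccc1` gives > 100000 nM, which is a limit of the assay and not a number.
Compound 3 `CC1=NN(c2cccc(Cl)c2)C(=O)C12C=CC(=O)C=C2c1ccccc1` gives 30100 nM.

Compound 2 thus stands at the top of the shown numbers, and its place is known only as a limit (the limit of > 100000 nM in this assay, at which 1 of the 3 values shown sits). The steps among the measured compounds all concern the aryl on the amide-type nitrogen in the ring: an at least 2.1-fold higher number from compound 1 to compound 2 (0.33 log units; beyond the scatter), a 1.5-fold lower number from compound 1 to compound 3 (0.19 log units; within the scatter) and an at least 3.3-fold lower number from compound 2 to compound 3 (0.52 log units; beyond the scatter). Compound 4 `CC1=NN(c2ccc(Br)cc2)C(=O)C12C=CC(=O)C=C2c1ccc(C)cc1` differs from compound 2 at another place: methyl in place of hydrogen on an aromatic carbon. None of the measured steps touches that phenyl, so no shown pair bears directly on this change; the measured steps only say that the compounds here are weak in this assay. The account therefore expects no step beyond the scatter: a step that the limit leaves unreadable from compound 2 to compound 4. Since compound 2 already sits at a limit, compound 4 is expected again to return only a limit or a weak number. Compound 4 is estimated at 120000 nM, between 40000 nM and 350000 nM.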

Compound 4, half-maximal inhibitory concentration: 15900 nM
The estimate for compound 4 lay 7.5-fold (0.88 log units) above the measured number; the measured number lies below the stated range.
By their numbers in this assay, from the lowest: compounds 4, 3 and 1 (each within the scatter of the next, the first and the last beyond it). At a limit, above all of these: compound 2.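

In this assay, going by these compounds alone, the earlier steps all concerned the aryl on the amide-type nitrogen, and this is the first to show that the other aryl also matters: a single methyl in place of hydrogen, turning phenyl into 4-methylphenyl, gives an at least 6.2-fold lower number from compound 2 to compound 4 (0.79 log units; beyond the scatter). A change of one heavy atom at this place is thus enough to bring a compound from a limit back to a readable number. The true size of the step stays unknown because compound 2 is known only as a limit: the limit of > 100000 nM in this assay, at which 1 of the 4 values shown sits.

The compounds shown leave open whether the methyl has a similar effect with the 4-methylphenyl or 3-chlorophenyl group on the nitrogen, since it appears here only with the 4-bromophenyl group. They also leave open how an ethyl, a methoxy, an amine or a carboxylic acid would fare at the same position.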